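The source may report more compounds than this note shows. Statements on the series, on what has been measured and on what is new or still open speak of the compounds shown alone.

Of the compounds shown here, three sharing one core have been tested in a functional assay on MDA-MB-231 cells (Homo sapiens) for antiproliferative activity, read by MTT assay, with a stated time of 72 h; on this read-out lower numbers stand for stronger inhibition and higher numbers for weaker inhibition. Compound 1 `CCCn1ccnc1-c1cc(OC)c(OC)c(OC)c1` carries a propyl on an aromatic nitrogen of that core; in this assay compound 1 gives > 100000 nM, which is a limit of the assay rather than a number. Compound 2 `COc1cc(OC)cc(-n2ccnc2-c2cc(OC)c(OC)c(OC)c2)c1` gives 45200 nM in this assay. Compound 3 `COc1cc(-c2nccn2-c2ccc(Br)cc2)cc(OC)c1OC` gives 8400 nM in this assay. The step of an at least 11-fold lower number from compound 1 to compound 3 (1.07 log units; beyond the scatter) shows that replacing the propyl with 4-bromophenyl brings a large gain, though only its lower bound is known because of the limit of > 100000 nM in this assay, at which 1 of the 3 values shown sits. Compound 4 `COc1ccc(-n2ccnc2-c2cc(OC)c(OC)c(OC)c2)cc1` differs from compound 1 by 4-methoxyphenyl in place of propyl on an aromatic nitrogen. Among the compounds with values here, this change is of the same kind as the one leading to compound 3, so a large step in the same direction is expected; compound 2, which carries 3,5-dimethoxyphenyl on an aromatic nitrogen and gives 45200 nM, suggests the gain may be smaller. Compound 4 is therefore expected to give about 15000 nM, most likely between 5000 nM and 60000 nM. That expectation amounts to an at least 6.6-fold lower number from compound 1 to compound 4 (0.82 log units; beyond the scatter).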

Compound 4, half-maximal inhibitory concentration: 2700 nM
Compound 4: middle estimate off by 5.6-fold (0.74 log units), on the high side, outside the stated range (below it).
By their numbers in this assay, from the lowest: compound 4; then compound 3; then compound 2. At a limit, above all of these: compound 1.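

The step of an at least 37-fold lower number from compound 1 to compound 4 (1.56 log units; beyond the scatter) in this assay shows that the large gain seen with 4-bromophenyl in place of propyl on this aromatic nitrogen also appears with a second group, 4-methoxyphenyl. The step of a 3.1-fold lower number from compound 3 to compound 4 (0.49 log units; beyond the scatter) adds something new: the gain depends not only on having an aromatic ring at this position but also on what that ring carries, since swapping bromo for methoxy on an aromatic carbon gives a modest further gain. The true size of the first step remains unknown, because compound 1 gives a limit and not a number: the limit of > 100000 nM in this assay, at which 1 of the 4 values shown sits.

The compounds shown leave open whether an amine or a carboxylic acid in place of the methoxy would extend or lose this gain. They also leave open how a longer chain in place of propyl would compare with these aromatic groups.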